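This account rests on a few compounds, and the source may have more. Where it says the series, first, only, none or still open, it means among the compounds named here.

Measured in a physicochemical assay for solubility, read by spectrophotometry, measured as kinetic solubility, at pH 8, tested at 500 uM; on this read-out lower numbers stand for lower solubility and higher numbers for higher solubility:
- compound 1 `Cn1ccc2ccc(-c3cc(Nc4ccccc4S(=O)(=O)N4CCOCC4)cc4nccnc34)cc21`: 5 ug/mL
- compound 2 `CN(C)C(=O)c1ccncc1Nc1cc(-c2ccc3ccn(C)c3c2)c2nccnc2c1`: 175 ug/mL

Of these two, compound 2 stands higher, with 175 ug/mL against compound 1 at 5 ug/mL, a gap beyond the usual scatter of this assay.

The next compound to read is compound 3 `CC(=O)N1CCCC(NC(=O)c2ccncc2Nc2cc(-c3ccc4ccn(C)c4c3)c3nccnc3c2)C1`, which keeps the core of compound 2 and carries (1-acetylpiperidin-3-yl)amino in place of dimethylamino on a carbonyl carbon.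

Among the compounds with values here, no two measured compounds differ in one place only, so the series offers no direct precedent for this change, and any expectation is a judgement. Within the data shown here, with compound 2 at 175 ug/mL, the higher of only two values, the expectation leans downward, though a result within the scatter would not surprise. The expected change is a 1.8-fold lower number from compound 2 to compound 3 (0.24 log units; within the scatter), a modest fall next to the gap between the two measured compounds. The estimate for compound 3 is 100 ug/mL, with an expected range of 30 ug/mL to 230 ug/mL.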

Compound 3, solubility: 212 ug/mL
For compound 3 the middle estimate is 2.1-fold (0.33 log units) below the measured one, within the range that was stated.
By their numbers in this assay, from the lowest: compound 1; then compounds 2 and 3 (each within the scatter of the next).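

On the carbonyl carbon whose other neighbour is an aromatic carbon, the series now has its first step that differs in one place only: in this assay (1-acetylpiperidin-3-yl)amino in place of dimethylamino gives a 1.2-fold higher number from compound 2 to compound 3 (0.08 log units; within the scatter) and so cannot be told apart from no change. This position therefore accepts a group of 10 heavy atoms in place of one of 3, bringing a six-membered non-aromatic ring, a hydrogen-bond donor and a hydrogen-bond acceptor, with no shift beyond the scatter of this read-out. No measurement at hand accounts for this outcome.

From the compounds shown here alone, a single replacement at this position cannot separate the parts of the entering group, so it remains open whether the acetyl or the piperidine ring matters to the read-out. Going by these compounds, it also remains open whether a piperidine with a free amine, a carboxylic acid or a longer chain in the same place would read alike in this assay as well.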